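Carbamate on the longer-chain core: compound 4 before measurement

The source may report more compounds than this note shows. Statements on the series, on what has been measured and on what is new or still open speak of the compounds shown alone.

The series shares one core, varied at the oxygen on the aromatic ring and in the side chain attached to the saturated ring. Compound 1 `CC(C)=CCC1Cc2c(O)cc(=O)n(CCCO)c2CC1(C)C` carries a free hydroxyl there; in a functional assay on PANC-1 cells (Homo sapiens) for inhibition, read by MTT assay, with a stated time of 24 h, tested at 10 uM (on this read-out lower numbers stand for less inhibition and higher numbers for more inhibition at the one concentration tested (going by the name of the read-out)), compound 1 gives 0%. Compound 2 `CC(C)=CCC1Cc2c(OC(=O)Nc3cccc(C(F)(F)F)c3)cc(=O)n(CCCO)c2CC1(C)C` carries a carbamate bearing a trifluoromethyl group; in this assay compound 2 gives 0%. Compound 3 `CC(C)=CCC/C(C)=C/CC1Cc2c(OCc3ccccc3)cc(=O)n(CCCO)c2CC1(C)C` carries a benzyl ether and the longer side chain; in this assay compound 3 gives 1.5%. Compound 3 sits at the upper end of the three numbers, but every gap between these three lies within the usual scatter, so none of them is separated from the others.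

Compound 4 `CC(C)=CCC/C(C)=C/CC1Cc2c(OC(=O)Nc3ccc(Cl)c(Cl)c3)cc(=O)n(CCCO)c2CC1(C)C` keeps the core and side chain of compound 3 and differs only at the oxygen: (3,4-dichlorophenyl)carbamoyl in place of benzyl on an oxygen on an aromatic ring. Among the measured compounds shown here, no step between measured compounds is available for this change, and the values of compound 2 and compound 1 show that a carbamate at this position gave no inhibition on the shorter-chain core.

For compound 4 the step in this assay is expected to be a number 0.5 percentage points higher from compound 3 to compound 4 (within the scatter), not beyond the scatter. Compound 4 is estimated at 2%, within 0% to 14%.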

Compound 4, a percentage reported as inhibition, at one concentration (the size of the read-out at that concentration, not a potency): 0%
Compound 4: the middle estimate sits 2 percentage points above what was measured; measured number inside the range.
By their numbers in this assay, from the lowest: compounds 1, 2, 4 and 3 (each within the scatter of the next).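

In this assay, among the compounds shown here, (3,4-dichlorophenyl)carbamoyl in place of benzyl on an oxygen on an aromatic ring gives a number 1.5 percentage points lower from compound 3 to compound 4 (within the scatter), the first step read at this oxygen alone, with the longer side chain and the rest of the core held fixed. Within this pair, the exchange adds a nitrogen, an oxygen, two chlorines, a hydrogen-bond donor and a hydrogen-bond acceptor to the substituent, yet the read-out does not separate the carbamate from the benzyl ether. No measured property is available that bears on this result.

From the compounds shown here alone, an amine or a carboxylic acid on this oxygen remains open, as does a longer chain in place of the hydroxyl-bearing chain on the shared core. The four compounds, taken in order of their numbers, each fall within the scatter of the next, so the compounds shown do not establish whether any change at this oxygen can move inhibition in this cell line at the one concentration tested.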